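Amide variation on a chlorothiophenesulfonamide CCR4 antagonist

The source may report more compounds than this note shows. Statements on the series, on what has been measured and on what is new or still open speak of the compounds shown alone.

Compound 1 `CC(=O)NCc1cccc(Cn2nc(NS(=O)(=O)c3ccc(Cl)s3)c3c(CO)cccc32)c1`, 1000 nM; compound 2 `COc1cccc2c1c(NS(=O)(=O)c1ccc(Cl)s1)nn2Cc1cccc(CNC(=O)C2COC2)c1`, 1000 nM; compound 3 `COc1cccc2c1c(NS(=O)(=O)c1ccc(Cl)s1)nn2Cc1cccc(CNC(=O)C2CCOCC2)c1`, 501 nM.

In an assay on isolated protein (blood) for antagonist activity at C-C chemokine receptor type 4 (Homo sapiens), read by flow cytometry, with a stated time of 30 min (on this read-out higher numbers stand for weaker binding and lower numbers for tighter binding), compound 3 holds the lowest of the three numbers, yet its gaps to compound 1 and to compound 2 both fall within the scatter, so no ranking among them can be read. Among the compounds with values here, the one measured step at this position, a 2.0-fold lower number from compound 2 to compound 3 (0.30 log units; within the scatter), was likewise within the scatter. Compound 4 `COc1cccc2c1c(NS(=O)(=O)c1ccc(Cl)s1)nn2Cc1cccc(CNC(=O)C(C)(C)N)c1` carries 1-amino-1-methylethyl in place of oxan-4-yl on a carbonyl carbon. Within the data shown here, no measured step covers an open-chain group with an amine at this carbonyl, so the expectation rests on the indifference seen so far: the step from compound 3 to compound 4 is expected to be a 1.2-fold higher number from compound 3 to compound 4 (0.08 log units; within the scatter), with nothing beyond the scatter foreseen. Compound 4 is therefore estimated at 600 nM, within 200 nM to 2000 nM.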

Compound 4, dissociation constant: 141 nM
Compound 4: the middle estimate sits 4.3-fold (0.63 log units) above what was measured; the measured number lies below the stated range.
By their numbers in this assay, from the lowest: compound 4; then compounds 3, 1 and 2 (each within the scatter of the next).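

Within the data shown here, on a carbonyl carbon, this position is not as indifferent as the earlier compounds suggested. In this assay, among these compounds, 1-amino-1-methylethyl in place of oxan-4-yl gives the first step beyond the scatter (a 3.6-fold lower number from compound 3 to compound 4 (0.55 log units; beyond the scatter)), and in place of oxetan-3-yl it gives a second (a 7.1-fold lower number from compound 2 to compound 4 (0.85 log units; beyond the scatter)). No measurement here accounts for these steps.

The compounds shown do not separate the contribution of the amine from that of the open, branched carbon chain. They also leave open how a plain tert-butyl group, a longer chain bearing the amine, or a carboxylic acid would read here.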